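Plasma half-life of a doubly esterified dianhydrohexitol

The source may report more compounds than this note shows. Statements on the series, on what has been measured and on what is new or still open speak of the compounds shown alone.

For the measured compounds named here, in an ADME assay on a cell-free system (plasma, Homo sapiens) for metabolic stability, with Plasma (Rattus norvegicus) as the target, read by HPLC, at pH 7.4 (on this read-out lower numbers stand for a shorter-lived compound and higher numbers for a longer-lived compound), compound 1 `CC(=O)Oc1ccccc1C(=O)O[C@H]1CO[C@H]2[C@@H]1OC[C@H]2O` gives 0.0183 h and compound 2 `CC(=O)Oc1ccccc1C(=O)O[C@H]1CO[C@H]2[C@@H]1OC[C@H]2OC(C)=O` gives 0.0095 h; the only measured step, a 1.9-fold lower number from compound 1 to compound 2 (0.28 log units; within the scatter), is within the scatter, so the two cannot be told apart. Compound 3 `COc1ccccc1C(=O)O[C@@H]1CO[C@H]2[C@@H]1OC[C@@H]2OC(=O)c1ccccc1OC(C)=O` differs from compound 2 by 2-methoxyphenyl in place of methyl on a carbonyl carbon. Going by the values given here, no measured step touches a carbonyl carbon, so nothing here speaks for a change beyond the scatter. Compound 3 is therefore expected near compound 2, with a 1.3-fold higher number from compound 2 to compound 3 (0.10 log units; within the scatter) in this assay. The estimate for compound 3 is 0.012 h, ranging from 0.004 h to 0.035 h.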

Compound 3, half-life: 0.0165 h
The estimate for compound 3 lay 1.4-fold (0.14 log units) below the measured number; the range from low to high includes it.
By their numbers in this assay, from the lowest: compounds 2, 3 and 1 (each within the scatter of the next).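

Putting 2-methoxyphenyl, with its six-membered aromatic ring, in place of methyl on the carbonyl carbon gives a 1.7-fold higher number from compound 2 to compound 3 (0.24 log units; within the scatter) in this assay. Even this far larger group therefore leaves the number within the scatter. Measured against the free hydroxyl, (2-methoxyphenyl)carbonyl gives a 1.1-fold lower number from compound 1 to compound 3 (0.04 log units; within the scatter) and so stays within the scatter too, which means that hydrogen, acetyl and this aromatic carbonyl group cannot be told apart at this oxygen. Nothing available explains the result. As far as these compounds go, whether an amine or a carboxylic acid on this carbonyl carbon, or a longer chain in place of methyl, would move the number beyond the scatter remains open.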